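The compounds below may be only part of what the source reports. "The series", "measured", "known", "first", "only" and "open" are said of these compounds alone.

Measured in an ADME assay on L1210/0 cells (Mus musculus) for cytotoxicity, with a stated time of 48 h; on this read-out higher numbers stand for weaker inhibition and lower numbers for stronger inhibition:

- Compound 1 `O=C(CI)NCc1cn([C@H]2C[C@H](O)[C@@H](CO)O2)c(=O)[nH]c1=O`: 107000 nM
- Compound 2 `C[S+]([O-])c1cn([C@H]2C[C@H](O)[C@@H](CO)O2)c(=O)[nH]c1=O`: > 200000 nM (a limit of the assay)
- Compound 3 `CS(=O)(=O)Cc1cn([C@H]2C[C@H](O)[C@@H](CO)O2)c(=O)[nH]c1=O`: > 200000 nM (a limit of the assay)

Compound 3 has no number in this assay, only a limit. The same is true of compound 2, and the shared position is the limit of > 200000 nM in this assay, at which 2 of the 3 values shown sit. Compound 4 `CCCC#Cc1cn([C@H]2C[C@H](O)[C@@H](CO)O2)c(=O)[nH]c1=O` is the next to be measured, and it differs from compound 3 as follows: pent-1-yn-1-yl in place of (methylsulfonyl)methyl on an aromatic carbon. Among the compounds with values here, the new group, pent-1-yn-1-yl, appears in no measured compound, so no measured step shows its effect directly.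

The nearest guides are an at least 1.8-fold higher number from compound 1 to compound 2 (0.27 log units; that floor lies within the scatter) and an at least 1.8-fold higher number from compound 1 to compound 3 (0.27 log units; that floor lies within the scatter), both with floors inside the scatter, and a step that the two limits leave unreadable from compound 2 to compound 3, which cannot be read. Within the data shown here, with compound 1 at 107000 nM as the one number available, a small step or none beyond the scatter is expected. The estimated step is an at least 1.3-fold lower number from compound 3 to compound 4 (0.12 log units; that floor lies within the scatter). For compound 4 the expected value is 150000 nM, with an estimated range of 40000 nM to 300000 nM.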

Compound 4, half-maximal inhibitory concentration: > 200000 nM
Compound 4 was reported as a limit (the forecaster's own chance of this, stated with the estimate: 50%); at least 1.3-fold (0.12 log units) between middle value and limit.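

In this assay compound 4 is reported only as a limit, > 200000 nM. Within the data shown here, an all-carbon group, pent-1-yn-1-yl, on this aromatic carbon therefore ends at the same place as the sulfur-bearing groups of the earlier compounds: the limit of > 200000 nM in this assay, at which 3 of the 4 values shown sit. The one readable step is an at least 1.8-fold higher number from compound 1 to compound 4 (0.27 log units; that floor lies within the scatter), while the two steps between limits cannot be read.

The compounds shown leave open whether any group at this position moves the read-out beyond the scatter, as the only number available remains that of compound 1. On these data alone, it is also open whether an amine, a carboxylic acid or a longer chain on the same aromatic carbon would give a number rather than a limit.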